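Methylation of the second phenolic oxygen on the amino analogue

The source may report more compounds than this note shows. Statements on the series, on what has been measured and on what is new or still open speak of the compounds shown alone.

The series shares one core, shown in compound 1 `Oc1ccc(/C=C/c2ccccc2O)cc1`, which in a functional assay on MCF7 cells (Homo sapiens) for inhibition, read by MTT assay, with a stated time of 2 days (on this read-out higher numbers stand for weaker inhibition and lower numbers for stronger inhibition), gives 21 ug/mL. Compound 2 `COc1ccc(/C=C/c2ccccc2O)cc1` carries a methyl on one phenolic oxygen and in this assay gives 17 ug/mL; compound 3 `Nc1ccc(/C=C/c2ccccc2O)cc1` carries an amino group in place of that hydroxy and in this assay gives 23 ug/mL. The steps among the three are a 1.2-fold lower number from compound 1 to compound 2 (0.09 log units; within the scatter), a 1.1-fold higher number from compound 1 to compound 3 (0.04 log units; within the scatter) and a 1.4-fold higher number from compound 2 to compound 3 (0.13 log units; within the scatter). Compound 3 thus holds the highest of the three numbers, but none of its steps to compound 1 or compound 2 reaches beyond the scatter.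

Compound 4 `COc1ccccc1/C=C/c1ccc(N)cc1` differs from compound 3 by methyl in place of hydrogen on an oxygen on an aromatic ring. Going by the values given here, the only measured step of the same kind is a 1.2-fold lower number from compound 1 to compound 2 (0.09 log units; within the scatter), the methylation of the remaining phenolic oxygen on the same core, and it stayed within the scatter. Among the compounds with values here, no measured pair combines the amino group with this methylation, so the amino analogue is judged by analogy alone. For this assay the expectation is therefore no step beyond the scatter, a 1.0-fold lower number from compound 3 to compound 4 (0.02 log units; within the scatter). For compound 4 the estimated value in this assay is 22 ug/mL, with a range from 11 ug/mL to 44 ug/mL.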

Compound 4, half-maximal inhibitory concentration: 3.2 ug/mL
Compound 4: the middle estimate sits 6.9-fold (0.84 log units) above what was measured, outside the stated range (below it).
By their numbers in this assay, from the lowest: compound 4; then compounds 2, 1 and 3 (each within the scatter of the next).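

Methylation is not a neutral change on every member of this series: in this assay, hydroxy to methoxy on the amino core gives a 7.2-fold lower number from compound 3 to compound 4 (0.86 log units; beyond the scatter), whereas compounds 1, 2 and 3 all lie within the scatter of one another. Going by these compounds alone, the oxygen methylated here is not the one methylated in compound 2, which keeps this hydroxy free while carrying its methyl on the oxygen whose place the amino group takes in compound 3. The same formal change therefore has a size that depends on its setting, with the partner group and the oxygen concerned both differing between the two pairs: the same change on two cores in this assay, a 1.2-fold lower number (0.09 log units; within the scatter) from compound 1 to compound 2 and a 7.2-fold lower number (0.86 log units; beyond the scatter) from compound 3 to compound 4, 5.8-fold (0.76 log units) apart, beyond the scatter of two such steps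

The compounds shown do not separate these two factors, so it remains open whether methoxy at this place would give a similarly large step with hydroxy or methoxy in place of the amino group. From the compounds shown here alone, it is also open whether the lower number extends to a longer chain on this oxygen, such as ethoxy, or survives replacing the amino group with dimethylamino or acetamido.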